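From Fluorophenyl to Methylphenyl: Expected Clearance of Compound 4

A few compounds are considered here, and "the series" means these few. Any claim that something is new, unique, unknown or untested is made for them only; others in the source may bear on it.

Three compounds have been measured:
compound 1 `CN1C[C@H](C(=O)Nc2ccccc2)[C@@H](c2ccc(/C=C/C(=O)Nc3ccccc3N)cc2)C1`, 67 mL/min/kg
compound 2 `CN1C[C@H](C(=O)Nc2ccc(F)cc2)[C@@H](c2ccc(/C=C/C(=O)Nc3ccccc3N)cc2)C1`, 34 mL/min/kg
compound 3 `CN1C[C@H](C(=O)Nc2ccc(Br)cc2)[C@@H](c2ccc(/C=C/C(=O)Nc3ccccc3N)cc2)C1`, 16 mL/min/kg

In an in vitro ADME assay on microsomes from liver (Mus musculus) for pharmacokinetics, read by LC-MS, with a stated time of 10 min, tested at 1 uM (on this read-out lower numbers stand for slow clearance and higher numbers for fast clearance), compound 2 stands second highest of the three numbers; its nearest neighbour is compound 1, a 2.0-fold lower number from compound 1 to compound 2 (0.29 log units; within the scatter), and its furthest is compound 3, a 2.1-fold lower number from compound 2 to compound 3 (0.33 log units; beyond the scatter). Compound 4 `Cc1cccc(NC(=O)[C@H]2CN(C)C[C@@H]2c2ccc(/C=C/C(=O)Nc3ccccc3N)cc2)c1` differs from compound 2 in one place: 3-methylphenyl in place of 4-fluorophenyl on an amide-type nitrogen. Among the measured compounds shown here, no measured step puts a methylphenyl in place of a fluorophenyl, so nothing bears on this change directly; the nearest comparisons are a 2.0-fold lower number from compound 1 to compound 2 (0.29 log units; within the scatter) for fluoro against hydrogen and a 4.2-fold lower number from compound 1 to compound 3 (0.62 log units; beyond the scatter) for bromo against hydrogen. With no methyl measured, the step for compound 4 is expected to stay within the scatter, a 1.5-fold higher number from compound 2 to compound 4 (0.17 log units; within the scatter). Compound 4 is therefore estimated at 50 mL/min/kg, with a range from 25 mL/min/kg to 100 mL/min/kg.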

Compound 4, clearance: 74 mL/min/kg
Compound 4: middle estimate off by 1.5-fold (0.17 log units), on the low side; the range from low to high includes it.
By their numbers in this assay, from the lowest: compound 3; then compounds 2, 1 and 4 (each within the scatter of the next, the first and the last beyond it).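

In this assay, not every group on this phenyl ring goes with a lower number: 3-methylphenyl stays level with the unsubstituted phenyl (a 1.1-fold higher number from compound 1 to compound 4 (0.04 log units; within the scatter)). It also stands apart from both halogen-bearing rings, 4-fluorophenyl (a 2.2-fold higher number from compound 2 to compound 4 (0.34 log units; beyond the scatter)) and 4-bromophenyl (a 4.6-fold higher number from compound 3 to compound 4 (0.67 log units; beyond the scatter)). Nothing shown here explains these differences.

Since methyl and the halogens sit at different places on the ring, the effects of the group and its place cannot be separated. From the compounds shown here alone, how an amine or a methoxy group on this ring would behave also remains open.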